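Propyl ester in a glycoside series: expectation before measurement

The compounds below may be only part of what the source reports. "The series", "measured", "known", "first", "only" and "open" are said of these compounds alone.

Compound 3 `C/C=C1/[C@H](O[C@@H]2O[C@H](CO)[C@@H](O)[C@H](O)[C@H]2O)OC=C(C(=O)OC)[C@H]1CC(=O)OCc1ccc(OC)c(OC)c1` stands at a limit rather than a number in a functional assay on SK-BR-3 cells (Homo sapiens) for antiproliferative activity, read by MTT assay, with a stated time of 72 h; on this read-out higher numbers stand for weaker inhibition and lower numbers for stronger inhibition: compound 3 gives > 15000 nM, and this is an assay limit. The same is true of compound 2 `C/C=C1/[C@H](O[C@@H]2O[C@H](CO)[C@@H](O)[C@H](O)[C@H]2O)OC=C(C(=O)OC)[C@H]1CC(=O)OC`, for which compound 2 gives > 15000 nM as a limit. Only compound 1 `C/C=C1/[C@H](O[C@@H]2O[C@H](CO)[C@@H](O)[C@H](O)[C@H]2O)OC=C(C(=O)OC)[C@H]1CC(=O)OCCC1CCCCC1` gives a measured number, and in this assay compound 1 gives 2000 nM. The two steps that carry information are an at least 7.5-fold higher number from compound 1 to compound 2 (0.87 log units; beyond the scatter) and an at least 7.5-fold higher number from compound 1 to compound 3 (0.87 log units; beyond the scatter), both read from the cyclohexylmethyl compound toward the limit (the limit of > 15000 nM in this assay, at which 2 of the 3 values shown sit). The step that the two limits leave unreadable from compound 2 to compound 3 cannot be sized, as both ends sit at that limit.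

Compound 4 `C/C=C1/[C@H](O[C@@H]2O[C@H](CO)[C@@H](O)[C@H](O)[C@H]2O)OC=C(C(=O)OC)[C@H]1CC(=O)OCCC` carries the change (ethyl in place of 3,4-dimethoxyphenyl on a saturated chain carbon bound to an oxygen next to a carbonyl group). Among the compounds with values here, no measured step addresses ethyl at this place; the two readable steps show only that the cyclohexylmethyl compound is the sole member with a number, and that hydrogen and 3,4-dimethoxyphenyl both sit at the limit. Compound 4 is therefore expected to lie at or near that limit, the step of a number no higher from compound 3 to compound 4 (the limit leaves the size open) being an expectation with no readable direction. Compound 4 is estimated at 15000 nM, in a range from 5000 nM to 40000 nM.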

Compound 4, half-maximal inhibitory concentration: > 15000 nM
Compound 4 ended at the assay's limit; the forecaster's own chance of this, stated with the estimate: 60%; the middle value sits exactly at the limit.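

In this assay, the change from compound 1 to compound 4 keeps the saturated chain and puts methyl in place of cyclohexyl, giving an at least 7.5-fold higher number from compound 1 to compound 4 (0.87 log units; beyond the scatter), so this chain without the cyclohexyl ring at its end does not keep the number seen for compound 1. Compound 4 gives a limit and not a number, which leaves compound 1 as the only compound shown with a measured value and adds a plain propyl ester to the compounds at the limit: the limit of > 15000 nM in this assay, at which 3 of the 4 values shown sit. The steps that link compound 4 to compound 2 and to compound 3 cannot be read, since both ends of each are limits, and no order can be drawn among these three compounds.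

The compounds shown leave open how far each of these three lies from the limit, and whether the measured activity of compound 1 depends on the cyclohexyl ring itself or would also appear with a longer chain such as hexyl or octyl. They also leave open whether an unsubstituted phenyl, a cyclopentyl or a terminal amine at the same chain end would give a number in this assay.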